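A few compounds are considered here, and "the series" means these few. Any claim that something is new, unique, unknown or untested is made for them only; others in the source may bear on it.

Measured in a functional assay on the whole organism (stomach) with Rattus norvegicus as the target; on this read-out higher numbers stand for an effect only at larger amounts of compound and lower numbers for an effect already at smaller amounts:
Compound 1 `CC/N=C(/NC#N)NCCCn1nc(-c2ccccc2)ccc1=O`: 78.3 mg/kg.
Compound 2 `CC/N=C(/NC#N)NCCCCn1nc(-c2ccccc2)c(C)cc1=O`: only a limit, > 100 mg/kg.
Compound 3 `CCC/N=C(/NC#N)NCCCn1nc(-c2ccccc2)ccc1=O`: 100 mg/kg.

From compound 3 to compound 1 the change is hydrogen in place of methyl on a saturated chain carbon, two bonds along the chain from a double-bonded nitrogen, and the measured step is a 1.3-fold lower number from compound 3 to compound 1 (0.11 log units; within the scatter). Compound 2 sits at the limit of > 100 mg/kg in this assay, at which 1 of the 3 values shown sits. The difference between the cores of compound 2 and compound 3 is not broken down here.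

Compound 4 `C/N=C(/NC#N)NCCCCn1nc(-c2ccccc2)c(C)cc1=O` is not yet measured; it differs from compound 2 by hydrogen in place of methyl on a saturated chain carbon bound to a double-bonded nitrogen. This is the same kind of change as from compound 3 to compound 1, but here the carbon carrying it is bound to the double-bonded nitrogen rather than two bonds along the chain from it. Since the measured step of a 1.3-fold lower number from compound 3 to compound 1 (0.11 log units; within the scatter) lies within the scatter, the expected step is likewise small, a step that the limit leaves unreadable from compound 2 to compound 4. Compound 4 is therefore estimated at 110 mg/kg, with a fair chance that only a limit is reported again.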

Compound 4, dose for half-maximal effect: > 100 mg/kg
Compound 4 was reported as a limit (the forecaster's own chance of this, stated with the estimate: 60%); the middle value does not contradict the limit.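

Compound 2 and compound 4 are both reported only as limits, and no step can be read between them. The compounds shown leave open whether hydrogen in place of methyl at this carbon changes the dose on their shared core.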